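A few compounds are considered here, and "the series" means these few. Any claim that something is new, unique, unknown or untested is made for them only; others in the source may bear on it.

Working notes on the trifluoromethyl diol amide series.

Among the compounds with values here, compound 1 `CCOc1ccc(-c2cnc(NC(=O)CCCCCCNC(=O)C(O)(O)C(F)(F)F)s2)cc1` and compound 2 `O=C(CCCCCCNC(=O)C(O)(O)C(F)(F)F)Nc1cccc(Br)c1` are the two members so far assessed in a functional assay on HCT-116 cells (Homo sapiens) for inhibition, read by colorimetric assay, with a stated time of 3 days; a higher number here means a weaker inhibitor, a lower number a stronger inhibitor. In this assay, within the data shown here, compound 1 gives 4050 nM, and in this assay compound 2 gives 3060 nM; the two figures sit within the usual scatter of each other, so neither compound can be set apart from the other, and no step between them is given here beyond what the two values themselves show.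

Compound 3 `COc1ccc(NC(=O)CCCCCCNC(=O)C(O)(O)C(F)(F)F)cc1` is not yet measured in this assay. It differs from compound 2 in one place: 4-methoxyphenyl in place of 3-bromophenyl on an amide-type nitrogen. Two values alone give no basis for a direction, and both stand in the low-micromolar region. The expectation is that the step of a 1.3-fold higher number from compound 2 to compound 3 (0.12 log units; within the scatter) stays within the scatter, or runs only slightly toward a higher number. Compound 3 is accordingly estimated at 4000 nM in this assay, with a likely range from 1500 nM to 11000 nM.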

Compound 3, half-maximal inhibitory concentration: 4520 nM
Beside the measured number, compound 3's estimate is 1.1-fold (0.05 log units) below it, within the range that was stated.
By their numbers in this assay, from the lowest: compounds 2, 1 and 3 (each within the scatter of the next).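

In this assay, within the data shown here, the replacement of 3-bromophenyl by 4-methoxyphenyl on the amide-type nitrogen gives a 1.5-fold higher number from compound 2 to compound 3 (0.17 log units; within the scatter), the first comparison that isolates a single place. This pair therefore gives no sign that the position distinguishes a bromine-bearing aryl group from a methoxy-bearing one, even though the entering group carries a hydrogen-bond acceptor and the leaving group carries none. Nothing available on these compounds speaks to the reason for this result.

Going by these compounds, whether the position responds to any other kind of group remains open, for example an amine or a carboxylic acid on the phenyl ring in place of the bromine. The compounds shown also leave open how a shorter or longer chain would read with the 3-bromophenyl group held fixed.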